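Methyl for Chloro on a Benzothiazole Anticonvulsant Core

The source may report more compounds than this note shows. Statements on the series, on what has been measured and on what is new or still open speak of the compounds shown alone.

Three compounds were tested in a functional assay on the whole organism (Hindlimb, strain albino) with Mus musculus as the target, in the maximal electroshock model, with a stated time of 0.5 h; on this read-out lower numbers stand for an effect already at smaller amounts and higher numbers for an effect only at larger amounts of compound. Compound 1 `COc1ccc(C2CC(Nc3nc4ccc(Cl)cc4s3)=NN2C(C)=O)cc1O` gives 127 umol/kg. Compound 2 `COc1ccc(C2CC(Nc3nc4ccc(C)cc4s3)=NN2C(C)=O)cc1O` gives 73.9 umol/kg. The change between them, (methyl in place of chloro on an aromatic carbon), produced a 1.7-fold lower number from compound 1 to compound 2 (0.24 log units; within the scatter). Compound 3 `O=C(/C=C/c1ccccc1)Nc1nc2ccc(Cl)cc2s1` gives 425 umol/kg, the highest number of the three; the difference between its core and that of compound 1 is not broken down here. Compound 4 `Cc1ccc2nc(NC(=O)/C=C/c3ccccc3)sc2c1` has not yet been tested in this assay. It differs from compound 3 by methyl in place of chloro on an aromatic carbon, the same change as from compound 1 to compound 2. The step is expected to be a 1.5-fold lower number from compound 3 to compound 4 (0.18 log units; within the scatter), resting on the earlier step of a 1.7-fold lower number from compound 1 to compound 2 (0.24 log units; within the scatter) seen on the other core. Compound 4 is therefore estimated at 280 umol/kg, with a range from 140 umol/kg to 560 umol/kg.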

Compound 4, dose for half-maximal effect: 380 umol/kg
For compound 4 the middle estimate is 1.4-fold (0.13 log units) below the measured one, and the stated range covers the measured number.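

In this assay the new step is a 1.1-fold lower number from compound 3 to compound 4 (0.05 log units; within the scatter), so on this core, as on the core of compound 1, methyl in place of chloro on an aromatic carbon stays within the scatter. The two steps agree with each other: the same change on two cores in this assay, a 1.7-fold lower number (0.24 log units; within the scatter) from compound 1 to compound 2 and a 1.1-fold lower number (0.05 log units; within the scatter) from compound 3 to compound 4, 1.5-fold (0.19 log units) apart, within the scatter of two such steps

This shows that the change carried across these two cores without a step beyond the scatter, but it does not show that the two groups are equivalent in general, and two small steps in a single assay cannot settle whether the change has any real effect. The compounds shown leave open how an amine, a nitrile or a longer chain at this place would read in this assay. They also leave open whether the step would hold on a third core.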